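Swapping Sulfamoyl for Ureido on a Shared Sulfonamide Core

The source may hold more compounds than are shown below. What is called first, only, known or untested is meant among the compounds shown, and "the series" means these compounds.

Measured so far in a functional assay on MDA-MB-231 cells (Homo sapiens) for antiproliferative activity, read by MTT assay, with a stated time of 72 h; on this read-out higher numbers stand for weaker inhibition and lower numbers for stronger inhibition:
- compound 1, `NS(=O)(=O)c1ccc(S(=O)(=O)Nc2cccc(-c3nc(-c4ccc(NC(=O)c5cccnc5)cc4Cl)no3)c2)cc1`, gives > 10000 nM
- compound 2, `CC(=O)Nc1ccc(S(=O)(=O)Nc2cccc(-c3nc(-c4ccc(NC(=O)c5cccnc5)c(Cl)c4)no3)c2)cc1`, gives 4500 nM
- compound 3, `CC(=O)Nc1ccc(S(=O)(=O)Nc2cccc(-c3nc(-c4ccc(NC(=O)c5cccnc5)c(C(F)(F)F)c4)no3)c2)cc1`, gives > 10000 nM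

As far as these compounds go, the value for compound 1 is a limit of the assay, not a number, so its true place is unknown beyond that edge. For the measured compounds named here, the only step measured here runs between compound 2 and compound 3: an at least 2.2-fold higher number from compound 2 to compound 3 (0.34 log units; beyond the scatter). That step concerns a different position of the shared core and does not touch the change now at hand.

Compound 4, `NC(=O)Nc1ccc(S(=O)(=O)Nc2cccc(-c3nc(-c4ccc(NC(=O)c5cccnc5)cc4Cl)no3)c2)cc1`, differs from compound 1 in one place: ureido in place of sulfamoyl on an aromatic carbon. Going by the values given here, no measured pair shows this exchange, so no step gives a direct guide to its size or direction. What remains is the standing of compound 1 at the limit, which is shared widely here because of the limit of > 10000 nM in this assay, at which 2 of the 3 values shown sit.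

The expectation for compound 4 therefore stays close to where compound 1 sits: an estimated step of a number no higher from compound 1 to compound 4 (the limit leaves the size open), with a fair chance that only a limit will again be reported. The estimated value for compound 4 is 10000 nM, within a range from 3000 nM to 30000 nM.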

Compound 4, half-maximal inhibitory concentration: 2800 nM
The estimate for compound 4 lay 3.6-fold (0.55 log units) above the measured number; the measured number lies below the stated range.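

In this assay, ureido in place of sulfamoyl gives an at least 3.5-fold lower number from compound 1 to compound 4 (0.55 log units; beyond the scatter), the first sign from a matched pair that the group at this place, para to a large group, can change the read-out. The two groups have the same count of heavy atoms and neither carries a net charge, but they differ in their atoms and in their hydrogen-bonding groups: ureido has 2 hydrogen-bond donors and 1 acceptor, while sulfamoyl has 1 donor and 2 acceptors. Compound 1 holds a limit of the assay rather than a number, so this step sets only a lower bound on the size of the change, and such limits are common here: the limit of > 10000 nM in this assay, at which 2 of the 4 values shown sit.

The compounds shown leave open whether this drop in the number is particular to ureido, or whether a simple amine, a carboxylic acid or a urea with a longer chain at the same place would also give it. They also leave open whether the same exchange would have a similar effect with the chloro group placed as in compound 2, since compound 2 also carries a different group at the changed place.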